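This account rests on a few compounds, and the source may have more. Where it says the series, first, only, none or still open, it means among the compounds named here.

Measured so far in a functional assay on MCF7 cells (Homo sapiens) for cytotoxicity, read by MTT assay and propidium iodide staining, with a stated time of 24 h; on this read-out higher numbers stand for weaker inhibition and lower numbers for stronger inhibition:

- compound 1 `CC(C)(C)c1ccc(-c2nnc(SCC(=O)c3ccccc3)o2)cc1` gives 50 nM
- compound 2 `CN(C)c1ccc(-c2nnc(SCC(=O)c3ccccc3)o2)cc1` gives 210 nM
- compound 3 `Cc1ccc(-c2nnc(SCC(=O)c3ccc(Br)cc3)o2)c(O)c1` gives 2070 nM

Compound 1 has the lowest number of the three, and both other compounds sit higher in this assay. Compound 4 `CC(C)(C)c1ccc(-c2nnc(SCC(=O)c3ccc(Br)cc3)o2)cc1` is still unmeasured. It departs from compound 1 by bromo in place of hydrogen on an aromatic carbon in a change from phenyl to 4-bromophenyl, with bromo in place of hydrogen on an aromatic carbon.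

Within the data shown here, the only measured single-place step is a 4.2-fold higher number from compound 1 to compound 2 (0.62 log units; beyond the scatter) (modest). That step is dimethylamino in place of tert-butyl on an aromatic carbon, so it offers a rough scale and no direct reading of this change. Compound 3 (at 2070 nM) also carries the 4-bromophenyl group, but it has no tert-butyl group, so its number cannot be assigned to bromo alone. Among the measured compounds shown here, no measured pair isolates bromo.

A modest move toward a higher number is therefore expected in this assay, and a result within the scatter would be no surprise. The estimated step is a 1.8-fold higher number from compound 1 to compound 4 (0.26 log units; within the scatter) and remains tentative. For compound 4 the expected value is 90 nM, with an estimated range from 25 nM to 400 nM.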

Compound 4, half-maximal inhibitory concentration: 1950 nM
For compound 4 the middle estimate is 22-fold (1.34 log units) below the measured one; the whole stated range lies below it.
By their numbers in this assay, from the lowest: compound 1; then compound 2; then compounds 4 and 3 (each within the scatter of the next).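

In this assay, among these compounds, the change from phenyl to 4-bromophenyl gives a 39-fold higher number from compound 1 to compound 4 (1.59 log units; beyond the scatter) as the first direct reading of this position, which the earlier compounds could not supply. A single bromo on an aromatic carbon para to a large group is thus labelled a large step in this series, while dimethylamino in place of tert-butyl gives a 4.2-fold higher number from compound 1 to compound 2 (0.62 log units; beyond the scatter) with a modest label. No supporting data on hand account for the size of the bromo step.

Still open is whether this step belongs to bromo specifically or extends to other groups at the same place, such as fluoro, chloro, methoxy or an amine, as the compounds shown offer only hydrogen and bromo there. Among the compounds shown here, also open is whether the bromo step keeps its size when tert-butyl is replaced by dimethylamino or another group, as compound 1 and compound 4 form the only pair here that isolates bromo.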